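The source may report more compounds than this note shows. Statements on the series, on what has been measured and on what is new or still open speak of the compounds shown alone.

Working notes on the series, varied only at the aryl end of the chain. Compound 1 `COC1=C(C)C(=O)/C(=C(O)/C=C/c2cccc(OC)c2)C(=O)C1(C)C` gives 3.3 ug/mL in a functional assay on KB cells (Homo sapiens) for cytotoxicity; on this read-out lower numbers stand for an effect already at smaller amounts and higher numbers for an effect only at larger amounts of compound; compound 2 `COC1=C(C)C(=O)/C(=C(O)/C=C/c2ccc(O)cc2)C(=O)C1(C)C` gives 3.8 ug/mL; compound 3 `COC1=C(C)C(=O)/C(=C(O)/C=C/c2c(C)cccc2C)C(=O)C1(C)C` gives 7.1 ug/mL. Compound 2 stands second highest of the three numbers, within the scatter of both neighbours, as a 1.2-fold higher number from compound 1 to compound 2 (0.06 log units; within the scatter) and a 1.9-fold higher number from compound 2 to compound 3 (0.27 log units; within the scatter) show. Compound 4 `COC1=C(C)C(=O)/C(=C(O)/C=C/c2cccs2)C(=O)C1(C)C` is still unmeasured and differs from compound 2 by thiophen-2-yl in place of 4-hydroxyphenyl on a double-bonded chain carbon bound to a double-bonded chain carbon. The aryl swaps already seen bear on it: a 1.2-fold higher number from compound 1 to compound 2 (0.06 log units; within the scatter) lies within the scatter, and a 2.2-fold higher number from compound 1 to compound 3 (0.33 log units; beyond the scatter) is only modest. No step beyond the scatter is therefore expected in this assay, and the step expected is a 1.2-fold higher number from compound 2 to compound 4 (0.07 log units; within the scatter). Compound 4 is estimated at 4.5 ug/mL, in the range 2 ug/mL to 10 ug/mL.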

Compound 4, concentration for half-maximal effect: 5.5 ug/mL
For compound 4 the middle estimate is 1.2-fold (0.09 log units) below the measured one; the measured number falls inside the stated range.
By their numbers in this assay, from the lowest: compounds 1, 2, 4 and 3 (each within the scatter of the next, the first and the last beyond it).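

In this assay a five-membered aromatic ring with sulfur as its hetero atom, thiophen-2-yl, stays within the scatter of all three phenyl-based groups on a double-bonded chain carbon bound to a double-bonded chain carbon (a 1.4-fold higher number from compound 2 to compound 4 (0.16 log units; within the scatter); a 1.7-fold higher number from compound 1 to compound 4 (0.22 log units; within the scatter); a 1.3-fold lower number from compound 3 to compound 4 (0.11 log units; within the scatter)). Replacing the six-membered carbon ring and the hydrogen-bond donor of compound 2 therefore produces no step beyond the scatter here. The compounds shown leave open whether an amine, a carboxylic acid or a longer chain in place of the aryl group would do so. No supporting data bear on why the numbers lie this close.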